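The source may report more compounds than this note shows. Statements on the series, on what has been measured and on what is new or still open speak of the compounds shown alone.

Measured so far in a functional assay on the whole organism (strain Swiss albino) for inhibition, with Mus musculus as the target, in the writhing test, with a stated time of 30 min, at a dose of 10 mg/kg by the oral route; a lower number here means a weaker effect, a higher number a stronger effect of the compound at the dose given:
compound 1, `Cc1c(C=O)cc(-c2ccc(S(C)(=O)=O)cc2)n1-c1ccccc1`, gives 23%.
compound 2, `Cc1c(C#N)cc(-c2ccc(S(C)(=O)=O)cc2)n1-c1cccc(F)c1`, gives 28%.
compound 3, `Cc1c(C#N)cc(-c2ccc(S(C)(=O)=O)cc2)n1-c1ccc(F)c(F)c1`, gives 19%.

In this assay compound 3 sits within the usual scatter of both compound 1 and compound 2; none of the three can be set apart from the others on these numbers. Among the measured compounds shown here, the one measured step that bears on the change ahead is a number 9 percentage points lower from compound 2 to compound 3 (within the scatter), where fluoro in place of hydrogen on the ring carried by the aromatic nitrogen did not move the number beyond the scatter. Compound 4, `Cc1c(C#N)cc(-c2ccc(S(C)(=O)=O)cc2)n1-c1ccccc1`, is not yet measured. The change is phenyl in place of 3,4-difluorophenyl on an aromatic nitrogen. For the measured compounds named here, it runs the fluoro step backwards and removes the fluorine of the 3,4-difluorophenyl altogether; no measured pair covers the plain phenyl against the monofluoro ring directly, though compound 1 carries a phenyl on the same nitrogen. Because a number 9 percentage points lower from compound 2 to compound 3 (within the scatter) stayed within the scatter, a step of a number 6 percentage points higher from compound 3 to compound 4 (within the scatter) is expected, not beyond the scatter. Compound 4 is therefore expected to give about 25%, between 12% and 38%.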

Compound 4, a percentage reported as inhibition, in the whole organism at one dose (the size of the read-out at that dose, not a potency): 28%
The estimate for compound 4 lay 3 percentage points below the measured number; measured number inside the range.
By their numbers in this assay, from the lowest: compounds 3, 1, 2 and 4 (each within the scatter of the next).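

In this assay, phenyl in place of 3,4-difluorophenyl on the aromatic nitrogen gives a number 9 percentage points higher from compound 3 to compound 4 (within the scatter) and hydrogen in place of the remaining fluoro gives no change at the digits printed from compound 2 to compound 4 (within the scatter), so the three rings at this position cannot be told apart on these numbers. Among the compounds shown here, the first direct reading of the group two ring bonds away, with phenyl held on the nitrogen, gives a number 5 percentage points higher from compound 1 to compound 4 (within the scatter) and leaves cyano and formyl equally unresolved. No measurement is available that would explain any of these results.

The compounds shown leave open whether a carboxylic acid in place of the cyano group, or a longer alkyl chain in place of the phenyl on the nitrogen, would move the number beyond the scatter. Going by these compounds, whether the four compounds would separate at another dose also remains open.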